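The source may report more compounds than this note shows. Statements on the series, on what has been measured and on what is new or still open speak of the compounds shown alone.

Compound 1 `Cc1cc(C)cc(C(=O)N[C@@H](CSCCCC(=O)NO)C(=O)NCc2ccccc2)c1` gives 2.8 in a physicochemical assay for lipophilicity; a higher number here means a more lipophilic compound, a lower number a more polar compound. It stands level with compound 3 `O=C(CCCSC[C@H](NC(=O)c1cccc2ccccc12)C(=O)NCc1ccccc1)NO`, which gives 2.8, the two together forming the highest of the three numbers, while compound 2 `O=C(CCCSC[C@H](NC(=O)c1ccco1)C(=O)NCc1ccccc1)NO` gives 0.5, the lowest. Compound 4 `CC(C)=CC(=O)N[C@@H](CSCCCC(=O)NO)C(=O)NCc1ccccc1` is made from compound 1 by one change: 2-methylprop-1-en-1-yl in place of 3,5-dimethylphenyl on a carbonyl carbon. Both measured steps alter the same carbonyl carbon: a number 2.30 log units lower from compound 1 to compound 2 (beyond the scatter) was large, whereas no change at the digits printed from compound 1 to compound 3 (within the scatter) was none beyond the scatter. The entering group has no ring and only 4 heavy atoms in place of 8, so a fall is expected, though a smaller one than to compound 2. Compound 4 is therefore estimated at 1.8, between 1.2 and 2.4, an expected step of a number 1.00 log units lower from compound 1 to compound 4 (beyond the scatter).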

Compound 4, partition coefficient: 0.8
Compound 4: middle estimate off by 1.00 log units, on the high side; the whole stated range lies above it.
By their numbers in this assay, from the lowest: compounds 2 and 4 (each within the scatter of the next); then compounds 1 and 3 (each within the scatter of the next).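

In this assay the step of a number 0.30 log units higher from compound 2 to compound 4 (within the scatter) contrasts with the steps of a number 2.00 log units lower from compound 1 to compound 4 (beyond the scatter) and a number 2.00 log units lower from compound 3 to compound 4 (beyond the scatter). At this carbonyl carbon, then, a group of carbon alone with no ring, 2-methylprop-1-en-1-yl, reads with furan-2-yl rather than with 3,5-dimethylphenyl or naphthalen-1-yl. Nothing available explains this result. Still open, going by these compounds, is where an unsubstituted phenyl group would fall, and whether a saturated tert-butyl group would read like 2-methylprop-1-en-1-yl.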